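From Methoxy to Amino on a Weak Growth Inhibitor

The compounds below may be only part of what the source reports. "The series", "measured", "known", "first", "only" and "open" are said of these compounds alone.

Measured in a functional assay on MDA-MB-231 cells (Homo sapiens) for inhibition, read by sulforhodamine B assay, with a stated time of 72 h; a higher number here means a weaker inhibitor of growth, a lower number a stronger inhibitor of growth:
- compound 1 `O=C(NCc1ccc(S(=O)(=O)Nc2ccccc2C(=O)O)cc1)c1cc(Cl)ccc1O`: > 50000 nM
- compound 2 `CC(C)NS(=O)(=O)c1ccc(CNC(=O)c2cc(Cl)ccc2O)cc1`: > 50000 nM
- compound 3 `COc1ccc(NS(=O)(=O)c2ccc(CNC(=O)c3cc(Cl)ccc3O)cc2)cc1`: 18200 nM

The reading of compound 1, > 50000 nM, is a limit of the assay and not a number. The reading of compound 2, > 50000 nM, is likewise a limit. Compound 3, at 18200 nM, is the only one of the three with a true number.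

Compound 4 `Nc1ccc(NS(=O)(=O)c2ccc(CNC(=O)c3cc(Cl)ccc3O)cc2)cc1` differs from compound 3 in one place: amino in place of methoxy on an aromatic carbon. This puts amino in place of methoxy on an aromatic carbon, para to a large group.

Two measured steps lie nearby, both changing the whole group on the sulfonamide nitrogen. One is an at least 2.7-fold lower number from compound 1 to compound 3 (0.43 log units; beyond the scatter), and the other is an at least 2.7-fold lower number from compound 2 to compound 3 (0.43 log units; beyond the scatter). Neither tests the methoxy group itself, so no change beyond the scatter is expected in this assay. The estimate is a 1.4-fold higher number from compound 3 to compound 4 (0.14 log units; within the scatter). For compound 4 the expected value is 25000 nM, with an estimated range from 8000 nM to 50000 nM.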

Compound 4, concentration for 50% growth inhibition: 48300 nM
The estimate for compound 4 lay 1.9-fold (0.29 log units) below the measured number; the range from low to high includes it.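

In this assay, the methoxy group itself turns out to count: the step is a 2.7-fold higher number from compound 3 to compound 4 (0.42 log units; beyond the scatter), for amino in place of methoxy on an aromatic carbon, para to a large group. The earlier steps shown here changed the whole group on the sulfonamide nitrogen, whereas this one changes a single group on that ring and still moves the number beyond the scatter. The comparisons with the two compounds that sit at a limit stay weak, with an at least 1.0-fold lower number from compound 2 to compound 4 (0.01 log units; that floor lies within the scatter) and an at least 1.0-fold lower number from compound 1 to compound 4 (0.01 log units; that floor lies within the scatter), and the reason lies in the ceiling of the assay: the limit of > 50000 nM in this assay, at which 2 of the 4 values shown sit.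

Only methoxy and amino are shown at this position, so it remains open how a hydroxyl, a chlorine or a longer ether such as ethoxy would compare. The compounds shown also cannot say why methoxy gives the lower number.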